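Swapping Naphthalen-2-yl for 4-Methylphenyl in a Cell Assay

This account rests on a few compounds, and the source may have more. Where it says the series, first, only, none or still open, it means among the compounds named here.

Three related compounds have been tested so far. In a functional assay on HT-29 cells (Homo sapiens) for inhibition, read by MTT assay, with a stated time of 72 h (on this read-out higher numbers stand for weaker inhibition and lower numbers for stronger inhibition), compound 1 `O=C1CS/C(=N\c2nc3cc(-c4ccc(Cl)cc4)sc3s2)N1` gives 13600 nM. In the same test, compound 2 `O=C1CS/C(=N\c2nc3cc(-c4ccc(Cl)cc4)[se]c3s2)N1` gives 42400 nM. Compound 3 `O=C1N/C(=N/c2nc3cc(-c4ccc(Cl)cc4)sc3s2)S/C1=C/c1ccc2ccccc2c1` gives > 50000 nM in this assay, and this is a limit of the assay, not a number. That reading is the limit of > 50000 nM in this assay, at which 1 of the 3 values shown sits. Compound 3 is therefore the only one of the three without a measured number.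

The next compound, compound 4 `Cc1ccc(/C=C2/S/C(=N\c3nc4cc(-c5ccc(Cl)cc5)sc4s3)NC2=O)cc1`, changes compound 3 in one place: 4-methylphenyl in place of naphthalen-2-yl on a double-bonded chain carbon bound to a double-bonded ring carbon. In words, 4-methylphenyl stands in place of naphthalen-2-yl on a double-bonded chain carbon bound to a double-bonded ring carbon.

For the measured compounds named here, no two measured compounds differ in only one place, which leaves no direct guide to the size of this change. The expectation rests loosely on compound 1 at 13600 nM and compound 2 at 42400 nM, whose readings show that close relatives can give numbers in this assay. A modest move toward stronger inhibition is expected, with an estimated at least 1.6-fold lower number from compound 3 to compound 4 (0.22 log units; that floor lies within the scatter). Another reading at the limit would be no surprise. For compound 4 the expected value is 30000 nM, with an estimated range from 8000 nM to 50000 nM.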

Compound 4, half-maximal inhibitory concentration: 45500 nM
Compound 4: middle estimate off by 1.5-fold (0.18 log units), on the low side, and the stated range covers the measured number.
By their numbers in this assay, from the lowest: compound 1; then compounds 2 and 4 (each within the scatter of the next). At a limit, above all of these: compound 3.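

Compound 4 gives this place, on a double-bonded chain carbon bound to a double-bonded ring carbon, its first actual number, where compound 3 offered only a limit. In this assay, putting 4-methylphenyl, with one aromatic ring, in place of naphthalen-2-yl, with two, gives an at least 1.0-fold lower number from compound 3 to compound 4 (0.04 log units; that floor lies within the scatter), so the second ring of naphthalen-2-yl is not shown to matter here. The true size of this step stays unknown because the reading for compound 3 is a limit of the assay and not a number: the limit of > 50000 nM in this assay, at which 1 of the 4 values shown sits.

The compounds shown leave open whether any group at this place can bring the number clearly down, since a single aromatic ring with a methyl group is the only case here that gives a number at all. On these data alone, it also remains unknown how a phenyl ring carrying an amine or a carboxylic acid, a pyridine ring, or a plain longer carbon chain would read at this same place.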